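Core substituent swap and rat liver stability: compound 3 to 4

The source may report more compounds than this note shows. Statements on the series, on what has been measured and on what is new or still open speak of the compounds shown alone.

In an ADME assay on S9 fraction from liver (Rattus norvegicus) for metabolic stability, read by LC-MS, using NADPH, with a stated time of 30 min (on this read-out higher numbers stand for a more stable compound and lower numbers for a less stable compound), compound 1 `CCCCCCCCc1ccc(OCC(=O)Cn2nnc(-c3ccc(S(=O)(=O)N(C)C)cc3)n2)cc1` gives 65%. Within the data shown here, compound 2 `CCCCCCCCc1ccc(OCC(=O)Cn2nnc(-c3cccs3)n2)cc1` gives 8%, and the step of a number 57 percentage points lower from compound 1 to compound 2 (beyond the scatter) is the only measured single-point step in this set. Compound 3 `CCCCCCCCc1ccc(OCC(=O)Cn2nnnc2-c2ccc(Cl)cc2)cc1` gives 45%, which is the second highest of the three numbers: compound 1 stands above it beyond the scatter, and compound 2 stands below it beyond the scatter. Compound 4 `CCCCCCCCc1ccc(OCC(=O)Cn2nnnc2C(=O)OC)cc1` has not yet been measured in this assay; it differs from compound 3 by methoxycarbonyl in place of 4-chlorophenyl on an aromatic carbon. Among the measured compounds shown here, the one measured step exchanges one ring group for another on an aromatic carbon of the shared core and was large; the change to compound 4 instead exchanges a ring group for a group with no ring, so no measured step covers it directly, and the expectation rests on the wide spread already seen among compounds 1, 2 and 3. On that basis a step beyond the scatter is expected, on balance a downward one, a number 20 percentage points lower from compound 3 to compound 4 (beyond the scatter). Compound 4 is therefore estimated at 25%, with a range from 5% to 55%.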

Compound 4, percent of the compound remaining: 38%
Compound 4: middle estimate off by 13 percentage points, on the low side, within the range that was stated.
By their numbers in this assay, from the lowest: compound 2; then compounds 4 and 3 (each within the scatter of the next); then compound 1.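

In this assay the exchange of 4-chlorophenyl for methoxycarbonyl gives a number 7 percentage points lower from compound 3 to compound 4 (within the scatter) and so leaves the read-out unresolved, even though a six-membered aromatic ring of carbon only gives way to a group with no ring, and 7 heavy atoms give way to 4. On this aromatic carbon between two ring nitrogen atoms, an aryl group is therefore not required for a number in this range, at least for this one pair. Among these compounds, the only other single-place exchange, a number 57 percentage points lower from compound 1 to compound 2 (beyond the scatter) on the core of compound 1, swaps one ring group for another at a differently placed attachment, so the two steps do not describe one position and the small step here does not contradict the large one there; no measurement is available that would explain either result.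

Going by these compounds, whether this position remains as undemanding with a carboxylic acid, an amide or a small amine in place of methoxycarbonyl stays open. Also open, on these data alone, is whether the same exchange on the core of compound 1 gives a similar step, and whether a shorter chain in place of octyl changes the picture.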